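Ester Ring Size on a Dihydropyrimidinone Scaffold

The source may hold more compounds than are shown below. What is called first, only, known or untested is meant among the compounds shown, and "the series" means these compounds.

Four compounds share one core, a six-membered non-aromatic ring with two nitrogens, and differ in two places: the aromatic ring attached to a saturated ring carbon and the small carbocycle at the end of the ester chain. In an assay on membranes from HeLa cells for displacement of a labelled ligand from adenosine receptor A3 (Homo sapiens), read by scintillation counting, with a stated time of 180 min, tested at 1 uM (a lower number here means less inhibition, a higher number more inhibition at the concentration tested (going by the name of the read-out)), compound 1 `CC1=C(C(=O)OCC2CC2)C(c2ccoc2)NC(=O)N1` gives 3%, compound 2 `CC1=C(C(=O)OCC2CCC2)C(c2ccoc2)NC(=O)N1` gives 2% and compound 3 `CC1=C(C(=O)OCC2CC2)C(c2cccs2)NC(=O)N1` gives 1%. All three numbers sit close together and are level with one another on this evidence.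

The change cyclobutyl in place of cyclopropyl on a saturated chain carbon bound to an oxygen next to a carbonyl group produced a number 1 percentage points lower from compound 1 to compound 2 (within the scatter). The cores of compound 1 and compound 3 differ by thiophen-2-yl in place of furan-3-yl on a saturated ring carbon, which gave a number 2 percentage points lower from compound 1 to compound 3 (within the scatter).

Compound 4 `CC1=C(C(=O)OCC2CCC2)C(c2cccs2)NC(=O)N1` has not been measured. It arises from compound 3 by cyclobutyl in place of cyclopropyl on a saturated chain carbon bound to an oxygen next to a carbonyl group, the same change that turned compound 1 into compound 2, at the same place. Because that earlier step a number 1 percentage points lower from compound 1 to compound 2 (within the scatter) stayed within the scatter, the step for compound 4 in this assay is expected to be a number 1 percentage points higher from compound 3 to compound 4 (within the scatter), again within the scatter. Compound 4 is therefore estimated to show 2%, most likely between -5% and 10%.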

Compound 4, a percentage reported as inhibition, at one concentration (the size of the read-out at that concentration, not a potency): 1%
Compound 4: the middle estimate sits 1 percentage points above what was measured, and the stated range covers the measured number.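

In this assay, cyclobutyl in place of cyclopropyl gives no change at the digits printed from compound 3 to compound 4 (within the scatter), and this step on the thiophen-2-yl core agrees with the earlier one on the furan-3-yl core: the same change on two cores in this assay, a number 1 percentage points lower (within the scatter) from compound 1 to compound 2 and no change at the digits printed (within the scatter) from compound 3 to compound 4, 1 percentage points apart, within the scatter of two such steps. Thiophen-2-yl in place of furan-3-yl gives a number 1 percentage points lower from compound 2 to compound 4 (within the scatter), and this swap likewise agrees across the cyclopropyl and cyclobutyl esters: the same change on two cores in this assay, a number 2 percentage points lower (within the scatter) from compound 1 to compound 3 and a number 1 percentage points lower (within the scatter) from compound 2 to compound 4, 1 percentage points apart, within the scatter of two such steps. Among these compounds, this agreement shows only that each swap stays within the scatter on both cores; with no step here of a size beyond the scatter, it does not show that a real effect on inhibition would carry from one core to another, and a reading at one concentration is not a potency.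

The compounds shown leave open whether a longer chain, an amine or a carboxylic acid in place of cyclobutyl would give a number beyond the scatter. They also leave open whether a step of that size, once found, would hold on both cores.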